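Carbamate to Cyclopropyl Amide on the Piperidine Nitrogen

This account rests on a few compounds, and the source may have more. Where it says the series, first, only, none or still open, it means among the compounds named here.

Three compounds share one core and differ only in the group carried on the carbonyl that sits on the ring nitrogen. Compound 2 `Cc1nc(S(C)(=O)=O)ccc1Oc1ncnc(OC2CCN(C(=O)OC3(C(F)(F)F)COC3)CC2)c1F` gives 29.3 nM in a functional assay on isolated protein for inhibition of Glucose-dependent insulinotropic receptor (Homo sapiens), read by HTRF and cAMP accumulation (a lower number here means that less compound is needed, a higher number that more compound is needed for the effect), and it stands lowest of the three numbers; compound 3 `Cc1nc(S(C)(=O)=O)ccc1Oc1ncnc(OC2CCN(C(=O)C3CCCC3)CC2)c1F` gives 72.8 nM and compound 1 `Cc1nc(S(C)(=O)=O)ccc1Oc1ncnc(OC2CCN(C(=O)OC(C)(C)C#N)CC2)c1F` gives 92.9 nM. The step of a 3.2-fold lower number from compound 1 to compound 2 (0.50 log units; beyond the scatter) and the step of a 2.5-fold higher number from compound 2 to compound 3 (0.40 log units; beyond the scatter) both lie beyond the scatter, while the step of a 1.3-fold lower number from compound 1 to compound 3 (0.11 log units; within the scatter) does not.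

Compound 4 `Cc1nc(S(C)(=O)=O)ccc1Oc1ncnc(OC2CCN(C(=O)C3(C)CC3)CC2)c1F` is not yet measured. It departs from compound 2 by 1-methylcyclopropyl in place of (3-(trifluoromethyl)oxetan-3-yl)oxy on a carbonyl carbon. The measured step that bears most directly on this change is a 2.5-fold higher number from compound 2 to compound 3 (0.40 log units; beyond the scatter), where an oxygen-linked group on the carbonyl gave way to a carbon ring bound directly to it, and the number rose modestly. Among the measured compounds shown here, the new ring is smaller than cyclopentyl and carries a methyl, and no measured pair shows what that alone does. On that basis compound 4 is expected to land somewhat higher than compound 2, with a step of about a 2.2-fold higher number from compound 2 to compound 4 (0.35 log units; beyond the scatter) expected. The estimate for compound 4 in this assay is 65 nM, with a range from 30 nM to 140 nM.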

Compound 4, half-maximal effective concentration: 761 nM
Beside the measured number, compound 4's estimate is 12-fold (1.07 log units) below it; the measured number lies above the stated range.
By their numbers in this assay, from the lowest: compound 2; then compounds 3 and 1 (each within the scatter of the next); then compound 4.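

In this assay, among the compounds shown here, this position proves far more demanding than the earlier compounds suggested, since replacing an oxygen-linked group with a carbon ring bound directly to the carbonyl had moved the number little or modestly in those compounds, as in a 1.3-fold lower number from compound 1 to compound 3 (0.11 log units; within the scatter). With such a carbon ring in both compounds and only the ring changed, there is a 10-fold higher number from compound 3 to compound 4 (1.02 log units; beyond the scatter), so a direct link from carbonyl to carbon ring does not by itself set the number, and the identity of the ring matters at least as much as the linkage. The same separation appears against both oxygen-linked groups, with a 26-fold higher number from compound 2 to compound 4 (1.41 log units; beyond the scatter) and an 8.2-fold higher number from compound 1 to compound 4 (0.91 log units; beyond the scatter), leaving compound 4 with the highest number of the four and showing that 1-methylcyclopropyl falls behind all three other groups on this carbonyl carbon.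

Nothing in the available data explains why 1-methylcyclopropyl differs so sharply from cyclopentyl. Whether plain cyclopropyl or cyclobutyl on the carbonyl carbon would track with compound 3 or with compound 4 remains open, so the compounds shown do not separate the effect of ring size from that of the methyl.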